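The source may hold more compounds than are shown below. What is called first, only, known or untested is meant among the compounds shown, and "the series" means these compounds.

Measured compounds:

Compound 1, `C#Cc1cn([C@@H]2O[C@H](CO)[C@@H](O)[C@H]2O)c2ncnc(NC)c12`: in a functional assay on HeLa S3 cells (Homo sapiens) for antiproliferative activity, read by XTT assay, with a stated time of 72 h (on this read-out lower numbers stand for stronger inhibition and higher numbers for weaker inhibition), compound 1 gives > 20000 nM, which is a limit of the assay and not a number.
Compound 2, `CNc1ncnc2c1c(I)cn2[C@@H]1O[C@H](CO)[C@@H](O)[C@H]1O`: in this assay compound 2 gives > 20000 nM, again a limit.
For the measured compounds named here, compound 3, `C#Cc1cn([C@@H]2O[C@H](CO)[C@@H](O)[C@H]2O)c2ncnc(OC)c12`: in this assay compound 3 gives 1730 nM, the only number among the three.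

Compound 3 differs from compound 1 in one place, (methoxy in place of methylamino on an aromatic carbon), and that single change carries the whole readable movement in the set: an at least 11-fold lower number from compound 1 to compound 3 (1.06 log units; beyond the scatter). Compound 2 differs from compound 1 in another place, (iodo in place of ethynyl on an aromatic carbon). The step between them stays unreadable because of the limit of > 20000 nM in this assay, at which 2 of the 3 values shown sit, so a step that the two limits leave unreadable from compound 1 to compound 2 gives no size.

Compound 4, `COc1ncnc2c1c(I)cn2[C@@H]1O[C@H](CO)[C@@H](O)[C@H]1O`, has not been measured. Going by the values given here, it differs from compound 3 by iodo in place of ethynyl on an aromatic carbon, the same change as the one from compound 1 to compound 2, made on the core of compound 3 instead. That earlier step sits between two limits, so there is no measured size to carry over.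

Compound 3 is therefore the only anchor. A small or modest step is expected, with a sizeable chance that only a limit is reported; the estimated change is a 2.3-fold higher number from compound 3 to compound 4 (0.36 log units; beyond the scatter). Compound 4 is expected to give 4000 nM, with a likely range from 1000 nM to 20000 nM.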

Compound 4, half-maximal inhibitory concentration: 14300 nM
For compound 4 the middle estimate is 3.6-fold (0.55 log units) below the measured one; measured number inside the range.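

In this assay, iodo in place of ethynyl on an aromatic carbon gives an 8.3-fold higher number from compound 3 to compound 4 (0.92 log units; beyond the scatter), while the same change on the core of compound 1 cannot be read, as both of its ends are limits of the assay and not numbers: the limit of > 20000 nM in this assay, at which 2 of the 4 values shown sit. The other change, methoxy in place of methylamino on an aromatic carbon, now stands on a second core and gives an at least 1.3-fold lower number from compound 2 to compound 4 (0.14 log units; that floor lies within the scatter), a step that rests on a limit and so sets only a floor. The two steps of this change therefore show no measured difference between the cores, but they also do not show that its size carries over from one core to the other: the same change on two cores in this assay, an at least 11-fold lower number (1.06 log units; beyond the scatter) from compound 1 to compound 3 and an at least 1.3-fold lower number (0.14 log units; that floor lies within the scatter) from compound 2 to compound 4; the limit leaves it open whether they differ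

The compounds shown leave open how other groups on the aromatic carbon of the five-membered aromatic ring, such as a nitrile, a methyl or a longer alkyne chain, would read in this assay. They also leave open how an ethoxy or a dimethylamino group would read in place of the methoxy of compound 3.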